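A Butyl Group Replaces Methoxy: What to Expect

The compounds below may be only part of what the source reports. "The series", "measured", "known", "first", "only" and "open" are said of these compounds alone.

Compound 1, `C=C1C(=O)OC[C@H]1CCOC(=O)Nc1ccc(Cl)cc1`: in a functional assay on RAW264.7 cells (Mus musculus) for inhibition, with a stated time of 30 min (on this read-out lower numbers stand for stronger inhibition and higher numbers for weaker inhibition), compound 1 gives 390 nM.
Compound 2, `C=C1C(=O)OC[C@H]1CCOC(=O)Nc1ccc(OC)cc1`: in this assay compound 2 gives 710 nM.

For the measured compounds named here, compound 2 holds the higher of the two numbers measured so far, but the only measured step, a 1.8-fold higher number from compound 1 to compound 2 (0.26 log units; within the scatter), lies within the scatter, so the two compounds cannot be ranked against each other with any confidence.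

Compound 3, `C=C1C(=O)OC[C@H]1CCOC(=O)Nc1ccc(CCCC)cc1`, is not yet measured. It differs from compound 2 in one place: butyl in place of methoxy on an aromatic carbon. Going by the values given here, no measured step involves a butyl group, so the only step that bears on this change is the swap of chloro for methoxy at the same position, and that step was small. With nothing in the data pointing to a large shift in either direction, the expectation for compound 3 is a number close to that of compound 2, and the step of a 1.2-fold lower number from compound 2 to compound 3 (0.07 log units; within the scatter) is estimated to stay within the scatter. Compound 3 is therefore expected to give about 600 nM in this assay, with a plausible range from 250 nM to 1500 nM.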

Compound 3, half-maximal inhibitory concentration: 620 nM
Estimate against measurement, compound 3: 1.0-fold (0.01 log units) below; low and high end bracket the measured number.
By their numbers in this assay, from the lowest: compounds 1, 3 and 2 (each within the scatter of the next).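

In this assay, replacing methoxy, with 2 heavy atoms and 1 hydrogen-bond acceptor, by butyl, with 4 heavy atoms and 0 hydrogen-bond acceptors, gives a 1.1-fold lower number from compound 2 to compound 3 (0.06 log units; within the scatter), so at this position neither the longer group nor the missing acceptor produces a difference that can be read. The comparison with the chloro compound ends the same way, with a 1.6-fold higher number from compound 1 to compound 3 (0.20 log units; within the scatter). The earlier pair offered only chloro and methoxy, whereas the series now shows that a four-carbon chain, para to a large group on the same six-membered aromatic ring, also stays within the scatter of both, so no ranking of these three groups can be drawn from these numbers.

Still open, going by these compounds, is whether this tolerance extends to groups of a different kind, such as an amine or a carboxylic acid, or to a chain longer than butyl, any of which might move the number well beyond the scatter. No supporting measurement is available to explain why these three groups read alike.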